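The source may hold more compounds than are shown below. What is called first, only, known or untested is meant among the compounds shown, and "the series" means these compounds.

Working notes on the series. Compound 3 `COc1nc(C)c(Nc2nc(Cl)cn([C@H](COC(=O)Nc3cccnc3)C3CC3)c2=O)cc1C` gives 10 nM in an assay on frontal cortex for displacement of a labelled ligand from corticotropin-releasing factor receptor 1 (Rattus norvegicus), with a stated time of 2 h (a higher number here means a weaker inhibitor, a lower number a stronger inhibitor), the highest number of the three measured; compound 2 `COc1nc(C)c(Nc2nc(Cl)cn([C@H](COC(=O)c3cccnc3)C3CC3)c2=O)cc1C` gives 5.2 nM, and compound 1 `COc1nc(C)c(Nc2nc(Cl)cn([C@H](COC(=O)c3ccccc3)C3CC3)c2=O)cc1C` gives 1.5 nM. The measured steps all change the group on the carbonyl carbon: a 3.5-fold higher number from compound 1 to compound 2 (0.54 log units; beyond the scatter), a 6.7-fold higher number from compound 1 to compound 3 (0.82 log units; beyond the scatter), a 1.9-fold higher number from compound 2 to compound 3 (0.28 log units; within the scatter). Compound 4 `COc1ccc(NC(=O)OC[C@H](C2CC2)n2cc(Cl)nc(Nc3cc(C)c(OC)nc3C)c2=O)c(C)n1` differs from compound 3 by 6-methoxy-2-methylpyridin-3-yl in place of pyridin-3-yl on an amide-type nitrogen. Among the measured compounds shown here, no measured step changes a substituent on this pyridine ring, so nothing here speaks directly to the size of the new step; the closest precedent is the weak drift seen in a 1.9-fold higher number from compound 2 to compound 3 (0.28 log units; within the scatter). Compound 4 is therefore expected to stay near compound 3, with a step of a 1.5-fold higher number from compound 3 to compound 4 (0.18 log units; within the scatter) in this assay. The estimate for compound 4 is 15 nM, expected to fall between 4 nM and 60 nM.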

Compound 4, half-maximal inhibitory concentration: 9.2 nM
The estimate for compound 4 lay 1.6-fold (0.21 log units) above the measured number, and the stated range covers the measured number.
By their numbers in this assay, from the lowest: compound 1; then compounds 2, 4 and 3 (each within the scatter of the next).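

In this assay, the amide-type nitrogen carries 6-methoxy-2-methylpyridin-3-yl as readily as pyridin-3-yl, with a 1.1-fold lower number from compound 3 to compound 4 (0.04 log units; within the scatter), so the first substituents shown on this pyridine ring leave the number unresolved from the unsubstituted ring. The same group, read as (6-methoxy-2-methylpyridin-3-yl)amino on the carbonyl carbon, gives a 1.8-fold higher number from compound 2 to compound 4 (0.25 log units; within the scatter) against pyridin-3-yl and a 6.1-fold higher number from compound 1 to compound 4 (0.79 log units; beyond the scatter) against phenyl, so substitution on the ring does not recover the gap to compound 1. No supporting evidence bears on why this position tolerates the change. As far as these compounds go, whether a carboxylic acid or an aminomethyl group on this pyridine ring would be tolerated equally remains open.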